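Swapping an ester for an ether on the core

The source may report more compounds than this note shows. Statements on the series, on what has been measured and on what is new or still open speak of the compounds shown alone.

Compound 1 `COC(=O)Cn1c2ccc([N+](=O)[O-])cc2c(=O)n1Cc1ccccc1` carries a methoxycarbonyl on a saturated chain carbon bound to an aromatic nitrogen of the shared core. In an ADME assay on L929 cells (Mus musculus) for cytotoxicity, read by resazurin assay, with a stated time of 48 h (on this read-out higher numbers stand for lower toxicity in this test and lower numbers for higher toxicity in this test), compound 1 gives 129000 nM, and among the three results shown it is the only one that is a definite number rather than a limit of the assay. Compound 2 `COC(=O)CCn1c2ccc([N+](=O)[O-])cc2c(=O)n1Cc1ccccc1` reaches only a limit, giving > 256000 nM in this assay. Compound 3 `CNC(=O)CCCn1c2ccc([N+](=O)[O-])cc2c(=O)n1Cc1ccccc1` likewise stops at a limit, giving > 256000 nM in this assay. The two measured steps that start from compound 1 both point upward: an at least 1.9-fold higher number from compound 1 to compound 2 (0.29 log units; that floor lies within the scatter) and an at least 1.9-fold higher number from compound 1 to compound 3 (0.29 log units; that floor lies within the scatter), and in both cases the lower bound is set by the limit of > 256000 nM in this assay, at which 2 of the 3 values shown sit.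

Compound 4 `CCOCCCn1c2ccc([N+](=O)[O-])cc2c(=O)n1Cc1ccccc1` is the unmeasured partner; its change from compound 1 is 2-ethoxyethyl in place of methoxycarbonyl on a saturated chain carbon bound to an aromatic nitrogen. Both known steps from compound 1 replace the methoxycarbonyl with a longer chain and land at the limit, so a step upward of similar size is expected, though not readable beyond the scatter. The estimate for compound 4 in this assay is 200000 nM, ranging from 100000 nM to 400000 nM. That expectation corresponds to a 1.6-fold higher number from compound 1 to compound 4 (0.19 log units; within the scatter).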

Compound 4, concentration lethal to 50% of the cells: 170000 nM
For compound 4 the middle estimate is 1.2-fold (0.07 log units) above the measured one, within the range that was stated.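

With a 1.3-fold higher number from compound 1 to compound 4 (0.12 log units; within the scatter) as a step of readable size in this assay and not a floor, the swap of methoxycarbonyl for 2-ethoxyethyl on a saturated chain carbon bound to an aromatic nitrogen leaves no difference that can be told from the scatter. A longer chain without the ester carbonyl therefore need not reach the limit, as the definite number of compound 4 shows. The steps of an at least 1.5-fold lower number from compound 3 to compound 4 (0.17 log units; that floor lies within the scatter) and an at least 1.5-fold lower number from compound 2 to compound 4 (0.17 log units; that floor lies within the scatter) remain floors, because each starts from a limit: the limit of > 256000 nM in this assay, at which 2 of the 4 values shown sit.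

As far as these compounds go, how far compound 2 and compound 3 truly lie from compound 4 stays open. So does whether an amine or a carboxylic acid at the end of this chain would move the number beyond the scatter from that of compound 1.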